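The source may report more compounds than this note shows. Statements on the series, on what has been measured and on what is new or still open speak of the compounds shown alone.

Measured compounds:
Compound 1 `Cc1nc(C)c([C@H](OC(C)(C)C)C(=O)O)c(N2CCC(C)(C)CC2)c1-c1ccc(OCCc2ccc(F)c(F)c2)cc1`: > 2 h
Compound 2 `Cc1nc(C)c([C@H](OC(C)(C)C)C(=O)O)c(N2CCC(C)(C)CC2)c1-c1ccc(OCCc2ccccn2)cc1`: 0.5 h

In an ADME assay on microsomes from liver (Homo sapiens) for metabolic stability, read by LC-MS, tested at 0.5 uM (on this read-out higher numbers stand for a longer-lived compound and lower numbers for a shorter-lived compound), compound 1 gives > 2 h, which is a limit of the assay rather than a number. Compound 1 thus sits at the limit of > 2 h in this assay, at which 1 of the 2 values shown sits. Among the compounds with values here, compound 2 gives 0.5 h in this assay, the only actual number in this set. Within the data shown here, the one measured step, an at least 4.0-fold lower number from compound 1 to compound 2 (0.60 log units; beyond the scatter), concerns a different change. Compound 3 `Cc1nc(C)c([C@H](OC(C)(C)C)C(=O)O)c(N2CCC(C)(C)CC2)c1-c1ccc(OCCc2cccnc2)cc1` differs from compound 2 by pyridin-3-yl in place of pyridin-2-yl on a saturated chain carbon, two bonds along the chain from an oxygen on an aromatic ring. Among the measured compounds shown here, no measured step moves the nitrogen within the pyridine ring, so no step beyond the scatter is expected: a 1.2-fold higher number from compound 2 to compound 3 (0.08 log units; within the scatter). Compound 3 is therefore estimated at 0.6 h, with a range of 0.25 h to 1.5 h.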

Compound 3, half-life: 0.367 h
Compound 3: the middle estimate sits 1.6-fold (0.21 log units) above what was measured; measured number inside the range.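

In this assay, moving the ring nitrogen, with pyridin-3-yl in place of pyridin-2-yl, gives a 1.4-fold lower number from compound 2 to compound 3 (0.13 log units; within the scatter), so the two pyridines cannot be told apart here. The change from 3,4-difluorophenyl gives an at least 5.4-fold lower number from compound 1 to compound 3 (0.73 log units; beyond the scatter), so the large step first seen with pyridin-2-yl also holds for pyridin-3-yl. The value of compound 1 is a limit, not a number: the limit of > 2 h in this assay, at which 1 of the 3 values shown sits.

Still open, going by these compounds, is whether pyridin-4-yl would sit with these two pyridines. Also open, on these data alone, is whether an unsubstituted phenyl or a phenyl with a single fluorine would sit with them or with compound 1.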